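The source may hold more compounds than are shown below. What is called first, only, known or untested is meant among the compounds shown, and "the series" means these compounds.

Compound 1 `COc1cc(C(=O)OCc2ccc(-c3ccc(Cl)cc3Cl)o2)cc(OC)c1OC` gives 24.4% in an assay on isolated protein for inhibition of high affinity 3',5'-cyclic-AMP phosphodiesterase 7A (Homo sapiens), read by scintillation proximity assay and cAMP accumulation, with a stated time of 20 min, tested at 10 uM; a higher number here means more inhibition at the concentration tested (going by the name of the read-out), a lower number less inhibition.
Compound 2 `CCOc1cc(C(=O)OCc2ccc(-c3ccc(Cl)cc3Cl)o2)cc(OCC)c1OCC` gives 3.7% in this assay.

Compound 2 holds the lower of these two numbers; compound 1 sits above it by a gap beyond the usual scatter, though the two structures differ in more than one place, so only the two values themselves can be compared. Compound 3 `CCOc1cc(C(=O)OCc2ccc(-c3ccc(C)cc3)o2)cc(OCC)c1OCC` is not yet measured. It differs from compound 2 by 4-methylphenyl in place of 2,4-dichlorophenyl on an aromatic carbon. Within the data shown here, with no measured step of this kind to lean on, no change beyond the scatter is expected from compound 2 to compound 3 in this assay, so a number 1.3 percentage points higher from compound 2 to compound 3 (within the scatter) is the estimated step. Compound 3 is expected to give about 5%, between -10% and 22%.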

Compound 3, a percentage reported as inhibition, at one concentration (the size of the read-out at that concentration, not a potency): 16.4%
Compound 3: middle estimate off by 11.4 percentage points, on the low side; measured number inside the range.
By their numbers in this assay, from the lowest: compound 2; then compounds 3 and 1 (each within the scatter of the next).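

Among these compounds, the first measured step at this position shows that inhibition responds to the aromatic group on the five-membered ring: in this assay, 4-methylphenyl in place of 2,4-dichlorophenyl gives a number 12.7 percentage points higher from compound 2 to compound 3 (beyond the scatter). This single swap removes both chlorines and adds a methyl, so it cannot show which of these changes matters. Nothing measured here explains the step.

Still open, as far as these compounds go, is how an unsubstituted phenyl, or a phenyl carrying only one chlorine or an amine, would behave here. Also open, from the compounds shown here alone, is whether the same swap would give a similar step on the trimethoxy ester of compound 1.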